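Replacing benzyl with phenyl on the oxygen of compound 1

The compounds below may be only part of what the source reports. "The series", "measured", "known", "first", "only" and "open" are said of these compounds alone.

Compound 1 `NS(=O)(=O)c1ccc(N2N=C(c3ccc(OCc4ccccc4)cc3)CC2c2ccc(F)cc2)cc1` gives 60000 nM
Compound 2 `NS(=O)(=O)c1ccc(N2N=C(c3ccc(OCc4ccccc4)cc3)CC2c2ccc(Cl)cc2)cc1` gives 15000 nM
Compound 3 `Cc1cccc(C2CC(c3ccc(OCc4ccccc4)cc3)=NN2c2ccc(S(N)(=O)=O)cc2)c1` gives 8000 nM

In an ADME assay on BHK-21 cells (Mesocricetus auratus) for cytotoxicity, read by MTT assay, with a stated time of 72 h (on this read-out lower numbers stand for higher toxicity in this test and higher numbers for lower toxicity in this test), compound 1 stands highest of the three, and both other compounds lie beyond the scatter from it. The next compound to be tested is compound 4 `NS(=O)(=O)c1ccc(N2N=C(c3ccc(Oc4ccccc4)cc3)CC2c2ccc(F)cc2)cc1`, which puts phenyl in place of benzyl on an oxygen on an aromatic ring. Within the data shown here, no measured step changes this group, so the data give no direct size for the change. The nearest guides are changes made elsewhere on the shared core. These are a 4.0-fold lower number from compound 1 to compound 2 (0.60 log units; beyond the scatter) and a 7.5-fold lower number from compound 1 to compound 3 (0.88 log units; beyond the scatter), both modest and both downward, while a 1.9-fold lower number from compound 2 to compound 3 (0.27 log units; within the scatter) stays within the scatter. Since compound 1 already sits at the top of the set at 60000 nM, a small lowering that does not go beyond the scatter is expected, though with wide uncertainty. The expected change is a 1.5-fold lower number from compound 1 to compound 4 (0.18 log units; within the scatter). For compound 4 the estimated value is 40000 nM, with an expected range from 15000 nM to 90000 nM.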

Compound 4, half-maximal cytotoxic concentration: 8000 nM
The estimate for compound 4 lay 5.0-fold (0.70 log units) above the measured number, and the stated range ends above it.
By their numbers in this assay, from the lowest: compounds 3, 4 and 2 (each within the scatter of the next); then compound 1.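

Among these compounds, the change from benzyloxy to phenoxy gives the first measured step on this oxygen, and in this assay it is a 7.5-fold lower number from compound 1 to compound 4 (0.88 log units; beyond the scatter), so this end of the molecule is not a silent place for the read-out. That step is as large as a 7.5-fold lower number from compound 1 to compound 3 (0.88 log units; beyond the scatter), so a change on the oxygen moves the number as far as the largest change shown on the saturated ring carbon, and compound 1 keeps the highest number of the four. Nothing shown accounts for the size of this step.

As far as these compounds go, whether phenyl in place of benzyl would lower the number similarly in compound 2 or compound 3 remains open. So does the outcome with other groups on this oxygen, such as methyl, a longer chain like 2-phenylethyl, or a chain ending in an amine.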